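A few compounds are considered here, and "the series" means these few. Any claim that something is new, unique, unknown or untested is made for them only; others in the source may bear on it.

Compound 1 `CC(C)(C)OC(=O)NCCNC(=O)CN1CN(c2ccccc2)C2(CCN(C(=O)c3ccc(C(C)(C)C)cc3)CC2)C1=O` is a spiro-fused hydantoin carrying a tert-butyl benzoyl group and a chain ending in a Boc-protected amine. In an assay on HEK293 cells for displacement of a labelled ligand from NPC1-like intracellular cholesterol transporter 1 (Homo sapiens) (on this read-out higher numbers stand for weaker inhibition and lower numbers for stronger inhibition), compound 1 gives 10900 nM. Compound 2 `CC(C)(C)OC(=O)NCCNC(=O)CN1CN(c2ccccc2)C2(CCN(C(=O)c3ccc(C4CCCCC4)cc3)CC2)C1=O` gives 5500 nM in this assay, and compound 3 `CC(C)(C)c1ccc(C(=O)N2CCC3(CC2)C(=O)N(CC(=O)N2CCCCC2CCO)CN3c2ccccc2)cc1` gives 6100 nM. Compound 1 thus has the largest of the three numbers, yet both steps away from it, a 2.0-fold lower number from compound 1 to compound 2 (0.30 log units; within the scatter) and a 1.8-fold lower number from compound 1 to compound 3 (0.25 log units; within the scatter), lie within the scatter of the assay.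

Compound 4 `CC(C)(C)OC(=O)NCCCCCNC(=O)CN1CN(c2ccccc2)C2(CCN(C(=O)c3ccc(C(C)(C)C)cc3)CC2)C1=O` differs from compound 1 by a lengthening of the chain: 3-((tert-butoxycarbonyl)amino)propyl in place of (tert-butoxycarbonyl)amino on a saturated chain carbon, two bonds along the chain from an amide-type nitrogen. The change sits in the same region as the step from compound 1 to compound 3, which showed no shift beyond the scatter; the step to compound 2 touches a distant part of the molecule and offers little guidance here. Neither measured step therefore suggests that the longer chain should move the number beyond the scatter in either direction.

The expectation for compound 4 is accordingly a value close to that of compound 1, estimated at 10000 nM with a range from 4000 nM to 25000 nM, which amounts to an expected step of a 1.1-fold lower number from compound 1 to compound 4 (0.04 log units; within the scatter).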

Compound 4, half-maximal inhibitory concentration: 13700 nM
Compound 4: middle estimate off by 1.4-fold (0.14 log units), on the low side, within the range that was stated.
By their numbers in this assay, from the lowest: compounds 2, 3, 1 and 4 (each within the scatter of the next, the first and the last beyond it).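

Within the data shown here, compound 4 gives the first look at chain length alone at this position, on a saturated chain carbon, two bonds along the chain from an amide-type nitrogen: the terminal (tert-butoxycarbonyl)amino group is kept, whereas the step to compound 3 replaced that whole end of the molecule. Going from 8 to 11 heavy atoms in this group, with the same counts of hydrogen-bond donors and acceptors, gives a 1.3-fold higher number from compound 1 to compound 4 (0.10 log units; within the scatter), so this lengthening has no effect that can be told from the scatter. Nothing measured here accounts for the result.

What the compounds shown leave open is whether a free primary amine or a carboxylic acid at the end of the chain, in place of the tert-butoxycarbonyl-protected amine, would shift the number beyond the scatter. They also leave open whether a still longer chain, or a shorter one, would do so.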